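Widening the amine on a fused thienopyrimidine TRPV1 antagonist

The compounds below may be only part of what the source reports. "The series", "measured", "known", "first", "only" and "open" are said of these compounds alone.

Three compounds were measured in a functional assay on HEK293 cells for antagonist activity at transient receptor potential cation channel subfamily V member 1 (Rattus norvegicus), read by calcium flux; on this read-out higher numbers stand for weaker inhibition and lower numbers for stronger inhibition. Compound 1 `FC(F)(F)c1ccc(Nc2ncnc3c2CCN(c2ncccc2C(F)(F)F)C3)cc1` gives 71 nM, compound 2 `CS(=O)(=O)c1ccccc1Nc1nc2c(Nc3ccc(C(F)(F)F)cc3)ncnc2s1` gives 221 nM, and compound 3 `FC(F)(F)c1ccc(Nc2nc(N3CCC3)nc3sc(Nc4c(Cl)cccc4Cl)nc23)cc1` gives 25 nM. Compound 3 therefore stands lowest of the three numbers; its nearest neighbour is compound 1, whose number lies beyond the scatter above it, and compound 2 lies further still, so compound 3 is the most potent of the three.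

Compound 4 `CC(C)N1CCN(c2nc(Nc3ccc(C(F)(F)F)cc3)c3nc(Nc4c(Cl)cccc4Cl)sc3n2)CC1` differs from compound 3 in one place: 4-isopropylpiperazin-1-yl in place of azetidin-1-yl on an aromatic carbon. Among the measured compounds shown here, no measured pair shows this exact change, so its effect must be guessed from the structural change alone. The shared core and both arylamino groups are kept, and the change is confined to the amine on the aromatic carbon between the two ring nitrogen atoms.

Compound 4 is expected to stay close to compound 3, with any step from compound 3 to compound 4 of about a 1.6-fold higher number from compound 3 to compound 4 (0.20 log units; within the scatter), which in this assay would be within or only just beyond the scatter. Compound 4 is estimated at 40 nM, in a range from 12 nM to 130 nM.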

Compound 4, half-maximal inhibitory concentration: 119 nM
Compound 4: the middle estimate sits 3.0-fold (0.47 log units) below what was measured; the measured number falls inside the stated range.
By their numbers in this assay, from the lowest: compound 3; then compounds 1, 4 and 2 (each within the scatter of the next, the first and the last beyond it).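

In this assay, putting 4-isopropylpiperazin-1-yl in place of azetidin-1-yl on the aromatic carbon between two ring nitrogen atoms gives a 4.8-fold higher number from compound 3 to compound 4 (0.68 log units; beyond the scatter), so this position responds to the choice of amine, and the larger group costs inhibition. The loss is modest, and compound 4 still reads 119 nM, so this carbon tolerates a six-membered ring carrying an isopropyl group without losing inhibition altogether. No evidence on the compounds accounts for the shift.

Among the compounds shown here, the single step leaves open whether the change follows the larger ring, the second ring nitrogen or the isopropyl group. It also leaves open how a plain piperazin-1-yl, a morpholin-4-yl or a pyrrolidin-1-yl would read at this carbon, with both arylamino groups kept.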